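The compounds below may be only part of what the source reports. "The series", "measured", "known", "first", "only" and "open" are said of these compounds alone.

Three compounds share one core and differ only in the group on one aromatic carbon. Compound 1 `CN(C)c1ccc(C#CC(C)(O)c2nccs2)cc1Nc1ncnc2[nH]ccc12` carries a dimethylamino group there and in an assay for inhibition of mitogen-activated protein kinase kinase kinase 14 (Homo sapiens), read by luminescence and ADP-Glo, with a stated time of 120 min, in the presence of a further agent that is not named here (a higher number here means a weaker inhibitor, a lower number a stronger inhibitor), compound 1 gives 22.5 nM. Compound 2 `CN(C)CCN(C)c1ccc(C#CC(C)(O)c2nccs2)cc1Nc1ncnc2[nH]ccc12` carries an open chain and gives 484 nM. Compound 3 `C[C@@H]1CN(c2ccc(C#CC(C)(O)c3nccs3)cc2Nc2ncnc3[nH]ccc23)CCN1` carries the 3-methylpiperazin-1-yl ring and gives 210 nM, the second highest of the three numbers: the step of a 9.3-fold higher number from compound 1 to compound 3 (0.97 log units; beyond the scatter) lies beyond the scatter, and so does the smaller step of a 2.3-fold lower number from compound 2 to compound 3 (0.36 log units; beyond the scatter).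

Compound 4 `CN1CCCN(c2ccc(C#CC(C)(O)c3nccs3)cc2Nc2ncnc3[nH]ccc23)CC1` has not yet been measured. It differs from compound 3 in one place: 4-methyl-1,4-diazepan-1-yl in place of 3-methylpiperazin-1-yl on an aromatic carbon. Going by the values given here, two measured steps bear on this. The step of a 9.3-fold higher number from compound 1 to compound 3 (0.97 log units; beyond the scatter) shows that moving from dimethylamino to a ring on this carbon raised the number markedly. The step of a 2.3-fold lower number from compound 2 to compound 3 (0.36 log units; beyond the scatter) shows that the ring gave a modestly lower number than the chain. Widening the ring by one carbon and removing its hydrogen-bond donor is a smaller change than either of those, so the expected step of a 1.3-fold higher number from compound 3 to compound 4 (0.12 log units; within the scatter) is modest, toward a somewhat higher number. Compound 4 is therefore expected to give 280 nM, within a range from 100 nM to 800 nM.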

Compound 4, half-maximal inhibitory concentration: 60.1 nM
The estimate for compound 4 lay 4.7-fold (0.67 log units) above the measured number, and the stated range ends above it.
By their numbers in this assay, from the lowest: compound 1; then compound 4; then compound 3; then compound 2.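

The size and make-up of the ring on this aromatic carbon matter in this assay, something compounds with a single ring could not show: the step of a 3.5-fold lower number from compound 3 to compound 4 (0.54 log units; beyond the scatter) comes from swapping 3-methylpiperazin-1-yl for 4-methyl-1,4-diazepan-1-yl, and it lies beyond the scatter. The seven-membered ring also stands well clear of the open chain, with the step of an 8.1-fold lower number from compound 2 to compound 4 (0.91 log units; beyond the scatter) giving a wider gap than the six-membered ring gave, yet it does not fully match the small group, as the step of a 2.7-fold higher number from compound 1 to compound 4 (0.43 log units; beyond the scatter) leaves dimethylamino with the lowest number of the four. Nothing measured here explains why the larger ring gives the lower number.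

The step from compound 3 to compound 4 changes several things at once: the ring size, the place of the methyl group, the hydrogen-bond donor and the defined stereocentre, so the effect of each stays unresolved. On these data alone, a 4-methylpiperazin-1-yl ring or a 1,4-diazepan-1-yl ring without the methyl group would help to separate ring size from the other changes, and how either would behave on this carbon remains open.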